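Trifluorophenyl in place of fluorophenyl on the amine nitrogen

The source may report more compounds than this note shows. Statements on the series, on what has been measured and on what is new or still open speak of the compounds shown alone.

In a functional assay on NALM-6 cells (Homo sapiens) for cytotoxicity, with a stated time of 72 h (a lower number here means that less compound is needed, a higher number that more compound is needed for the effect), compound 1 (`C=C[C@@](C)(/C=C/c1ccc(OC)cc1)CCC=C(C)C`) gives > 43400 nM, which is a limit. Compound 2 (`C=C[C@@](C)(/C=C/c1ccc(Nc2ccc(F)cc2)cc1)CCC=C(C)C`) gives > 43400 nM, which is also a limit. Among the compounds with values here, the only measured step, a step that the two limits leave unreadable from compound 1 to compound 2, provides no size to carry forward, and the series so far amounts to the limit of > 43400 nM in this assay, at which 2 of the 2 values shown sit. Compound 3 (`C=C[C@@](C)(/C=C/c1ccc(Nc2c(F)cc(F)cc2F)cc1)CCC=C(C)C`) differs from compound 2 by 2,4,6-trifluorophenyl in place of 4-fluorophenyl on a nitrogen on an aromatic ring. This places 2,4,6-trifluorophenyl in place of 4-fluorophenyl on a nitrogen on an aromatic ring. In this assay the expected change is no more than scatter, with no direction: a step that the limit leaves unreadable from compound 2 to compound 3. For compound 3 the estimated value is 45000 nM, with an expected range of 20000 nM to 90000 nM.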

Compound 3, half-maximal effective concentration: > 43400 nM
Compound 3 was reported as a limit (the forecaster's own chance of this, stated with the estimate: 75%); the middle value is on the limit's open side.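

Compound 2 and compound 3 are both reported only as limits, and the step between them cannot be read. The compounds shown leave open which structural change, if any, would give a readable value in this assay.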